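Replacing 4-chlorophenyl with 3-fluorophenyl in compound 4

The compounds below may be only part of what the source reports. "The series", "measured", "known", "first", "only" and "open" are said of these compounds alone.

Compounds measured so far in an ADME assay on BJ cells (Homo sapiens) for cytotoxicity, with a stated time of 72 h (on this read-out higher numbers stand for an effect only at larger amounts of compound and lower numbers for an effect already at smaller amounts), are these:
- Compound 1 `Cc1ccc(-c2nc3ccccc3s2)cc1NC(=O)c1cc([N+](=O)[O-])c(N(C)C)cc1Cl` gives > 25000 nM as a limit of the assay
- Compound 2 `O=C(Nc1nc2c(Cl)cccc2s1)c1cc([N+](=O)[O-])ccc1Cl` gives > 27000 nM as a limit of the assay
- Compound 3 `O=C(Nc1nc(-c2ccc(Cl)cc2)cs1)c1cc([N+](=O)[O-])ccc1Cl` gives 18000 nM as a number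

Among the measured compounds shown here, compound 3 stands at 18000 nM and holds the only number here. The other two values are limits. Compound 4 `O=C(Nc1nc(-c2cccc(F)c2)cs1)c1cc([N+](=O)[O-])ccc1Cl` has not yet been measured. It differs from compound 3 in one place, with 3-fluorophenyl in place of 4-chlorophenyl on an aromatic carbon of the shared core. For the measured compounds named here, no measured pair here differs in one place alone, so the data show no size for such a change. A change beyond the usual scatter is not expected, and neither direction is favoured. The estimate rests on compound 3 at 18000 nM as its starting point. The estimated move is a 1.1-fold higher number from compound 3 to compound 4 (0.05 log units; within the scatter) and is expected to stay within the scatter. In this assay compound 4 is estimated at 20000 nM with an expected range from 9000 nM to 40000 nM overall.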

Compound 4, half-maximal effective concentration: 24000 nM
Compound 4: the middle estimate sits 1.2-fold (0.08 log units) below what was measured; the measured number falls inside the stated range.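

In this assay, the exchange of 4-chlorophenyl for 3-fluorophenyl on the aromatic carbon next to the ring nitrogen gives a 1.3-fold higher number from compound 3 to compound 4 (0.12 log units; within the scatter), the first size shown for a change in one place alone. At this position, the read-out therefore does not separate the two groups, although the halogen and its place on the phenyl ring differ together, so the step cannot be divided between those two differences. Nothing in the data shown accounts for the size of this step.

The compounds shown leave open what either halogen contributes alone, as neither 3-chlorophenyl nor 4-fluorophenyl stands among them. They also leave open whether an amine or a carboxylic acid on the phenyl ring, or a longer chain in its place, would move the number beyond the scatter.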